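Aryl swap at the saturated ring carbon: from styryl to methoxyphenyl

The compounds below may be only part of what the source reports. "The series", "measured", "known", "first", "only" and "open" are said of these compounds alone.

Compound 1 `N#CC1=C(N)N(c2ccc(S(N)(=O)=O)cc2)C2=C(CCCC2)C1c1ccccc1O`: 40%
Compound 2 `N#CC1=C(N)N(c2ccc(S(N)(=O)=O)cc2)C2=C(CCCC2)C1/C=C/c1ccccc1`: 70%

In a functional assay on Ehrlich cells (Mus musculus) for cytotoxicity, read by trypan blue exclusion, with a stated time of 2 h, tested at 25 ug/mL (on this read-out higher numbers stand for a stronger effect at the one concentration tested and lower numbers for a weaker effect), compound 2 gives 70%, the higher of the two numbers, with compound 1 at 40%. Compound 3 `COc1ccccc1C1C(C#N)=C(N)N(c2ccc(S(N)(=O)=O)cc2)C2=C1CCCC2` carries the change (2-methoxyphenyl in place of 2-phenylethenyl on a saturated ring carbon). Within the data shown here, no measured step covers this exact exchange; the only one at hand is a number 30 percentage points higher from compound 1 to compound 2 (beyond the scatter), which goes in the opposite direction and removes the 2-phenylethenyl group. Since compound 3 returns to a 2-substituted phenyl group on that carbon, a drop back toward compound 1 is expected, of about a number 22 percentage points lower from compound 2 to compound 3 (beyond the scatter). Compound 3 is estimated at 48%, within 30% to 68%.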

Compound 3, a percentage reported as activity, at one concentration (the size of the read-out at that concentration, not a potency): 40%
The estimate for compound 3 lay 8 percentage points above the measured number; low and high end bracket the measured number.
By their numbers in this assay, from the lowest: compounds 1 and 3 (each within the scatter of the next); then compound 2.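

In this assay the exchange of 2-phenylethenyl for 2-methoxyphenyl on the saturated ring carbon gives a number 30 percentage points lower from compound 2 to compound 3 (beyond the scatter) and so leaves compound 2 alone at the top of these three. Methyl in place of hydrogen on the aromatic oxygen gives no change at the digits printed from compound 1 to compound 3 (within the scatter), so capping that oxygen does not separate the two phenyl-bearing compounds on this read-out. Nothing available here explains either step. Still open, from the compounds shown here alone, is whether a phenyl group carrying an amine or a carboxylic acid would stay with compound 1 and compound 3, or whether a longer chain on this carbon would stay with compound 2.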